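The source may hold more compounds than are shown below. What is called first, only, known or untested is meant among the compounds shown, and "the series" means these compounds.

Values in a physicochemical assay for solubility, in phosphate buffer, at pH 7.4 (on this read-out higher numbers stand for higher solubility and lower numbers for lower solubility), stand as follows:
- compound 1 `CCOC(=O)c1c(-c2ccc(Cl)cc2)[nH]c2cccc(OC)c2c1=O` gives > 100000 nM as a limit of the assay
- compound 2 `CCOC(=O)c1c(-c2ccc(C(C)(C)C)cc2)[nH]c2cccc(OC)c2c1=O` gives 1000 nM

Compound 1 stands at the limit of > 100000 nM in this assay, at which 1 of the 2 values shown sits, and this is a limit, not a number. Compound 3 `CCOC(=O)c1c(-c2ccccc2Cl)[nH]c2cccc(OC)c2c1=O` is not yet measured: 2-chlorophenyl stands in place of 4-chlorophenyl on an aromatic carbon, with the same atoms joined differently (2-chlorophenyl in place of 4-chlorophenyl on an aromatic carbon). Among the compounds with values here, only one measured step starts from compound 1, and it exchanges the group rather than moving it: tert-butyl in place of chloro on an aromatic carbon gives an at least 100-fold lower number from compound 1 to compound 2 (2.00 log units; beyond the scatter) and is large, beyond the scatter. Within the data shown here, no measured step shifts the chloro group, so that size does not carry over. In this assay a step within the scatter is therefore expected, with no direction favoured by the data. The estimated step is an at least 1.2-fold lower number from compound 1 to compound 3 (0.09 log units; that floor lies within the scatter) and no more than that is expected. Compound 3 is expected at 80000 nM (estimated range 25000 nM to 200000 nM).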

Compound 3, solubility: > 100000 nM
Compound 3: a limit, no number; the forecaster's own chance of this, stated with the estimate: 55%; middle value at least 1.2-fold (0.09 log units) from the limit.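

In this assay, within the data shown here, compound 1 and compound 3 both stand at a limit rather than a number, and no step between them can be read: the limit of > 100000 nM in this assay, at which 2 of the 3 values shown sit.

The compounds shown leave open how 2-chlorophenyl and 4-chlorophenyl compare on the shared core in this read-out.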